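From Octylsulfanyl to Ethoxy: A Cytotoxicity Expectation

A few compounds are considered here, and "the series" means these few. Any claim that something is new, unique, unknown or untested is made for them only; others in the source may bear on it.

Compound 1 `CCCSc1nc(N)nc2c1ncn2/C=C1/CC1(CO)CO` and compound 2 `CCCCCCCCSc1nc(N)nc2c1ncn2/C=C1/CC1(CO)CO` share one core. In an ADME assay on BCBL1 cells (Homo sapiens) for cytotoxicity, with a stated time of 7 days (on this read-out lower numbers stand for higher toxicity in this test and higher numbers for lower toxicity in this test), compound 1 gives only an assay limit, > 20000 nM. Compound 2 in this assay also gives only a limit, > 20000 nM. Within the data shown here, the single measured step is a step that the two limits leave unreadable from compound 1 to compound 2, and both values sit at the limit of > 20000 nM in this assay, at which 2 of the 2 values shown sit, so compound 2 stands at the limit without a number. Compound 3 `CCOc1nc(N)nc2c1ncn2/C=C1/CC1(CO)CO` carries ethoxy in place of octylsulfanyl on an aromatic carbon. No sized step can be read from the measured pair, so nothing beyond the scatter is expected in this assay. Compound 3 is therefore estimated at 30000 nM, between 10000 nM and 100000 nM. The expected step is a step that the limit leaves unreadable from compound 2 to compound 3.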

Compound 3, half-maximal cytotoxic concentration: > 20000 nM
Compound 3 was reported as a limit; the forecaster's own chance of this, stated with the estimate: 75%; the middle value is on the limit's open side.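

No step can be read among compound 1, compound 2 and compound 3 in this assay because all three values are limits: the limit of > 20000 nM in this assay, at which 3 of the 3 values shown sit. On these data alone, whether the three compounds differ in half-maximal cytotoxic concentration at all, and by how much, stays open.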